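One Aryl Swap, Two Cores, One Unknown

A few compounds are considered here, and "the series" means these few. Any claim that something is new, unique, unknown or untested is made for them only; others in the source may bear on it.

Compound 1 `Cc1ccc(-c2cn(C/C=C3\OC(=O)C(OCc4ccccc4)=C3OCc3ccccc3)nn2)cc1` and compound 2 `O=C1O/C(=C\Cn2cc(-c3cc(F)cc(F)c3)nn2)C(OCc2ccccc2)=C1OCc1ccccc1` share a core that carries an aromatic ring with one 4-methylphenyl or one 3,5-difluorophenyl group. In a functional assay on HepG2 cells (Homo sapiens) for antiproliferative activity, read by MTT assay, with a stated time of 72 h (a lower number here means a stronger inhibitor, a higher number a weaker inhibitor), compound 1 gives > 100000 nM, which is a limit of the assay rather than a number. Compound 2 likewise gives > 100000 nM, also a limit. Because (the limit of > 100000 nM in this assay, at which 2 of the 3 values shown sit), the change 3,5-difluorophenyl in place of 4-methylphenyl on an aromatic carbon gives a step that the two limits leave unreadable from compound 1 to compound 2. Compound 3 `Cc1ccc(-c2cn(C[C@H](O)[C@H]3OC(=O)C(OCc4ccccc4)=C3OCc3ccccc3)nn2)cc1` has a different core; the difference between the two cores is not broken down here. In this assay compound 3 gives 8770 nM. Compound 4 `O=C1O[C@H]([C@@H](O)Cn2cc(-c3cc(F)cc(F)c3)nn2)C(OCc2ccccc2)=C1OCc1ccccc1` is not yet measured and differs from compound 3 by 3,5-difluorophenyl in place of 4-methylphenyl on an aromatic carbon, the same change as before. Compound 4 is expected to give about 8000 nM in this assay. That expectation means a step of a 1.1-fold lower number from compound 3 to compound 4 (0.04 log units; within the scatter), and it rests on compound 3 with 8770 nM, since the earlier step is unreadable.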

Compound 4, half-maximal inhibitory concentration: 11600 nM
Compound 4: middle estimate off by 1.5-fold (0.16 log units), on the low side; measured number inside the range.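

On the core of compound 3, 3,5-difluorophenyl in place of 4-methylphenyl gives a 1.3-fold higher number from compound 3 to compound 4 (0.12 log units; within the scatter) in this assay, so this measurement does not separate the two compounds. For the compounds shown here, the same change on the core of compound 1 gives a step that cannot be read, because compound 1 and compound 2 both sit at a limit of the assay rather than at a number: the limit of > 100000 nM in this assay, at which 2 of the 4 values shown sit. With only one readable step, the data do not show whether the change behaves alike on the two cores.

From the compounds shown here alone, it remains open whether a phenyl ring carrying an amine or a carboxylic acid, in place of these two groups, would give a step beyond the scatter on the core of compound 3. Also open, going by these compounds, is what a longer chain linking that core to the five-membered aromatic ring would do.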